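The source may report more compounds than this note shows. Statements on the series, on what has been measured and on what is new or still open speak of the compounds shown alone.

Of the compounds shown here, three of a shared core have been tested in a functional assay on HL-60 cells (Homo sapiens) for antiproliferative activity, read by MTT assay, with a stated time of 48 h; on this read-out lower numbers stand for stronger inhibition and higher numbers for weaker inhibition. Compound 1 `N#Cc1nc2c(-c3nc4ccccc4[nH]3)c(N)n(CCN3CCCC3)c2nc1C#N` gives 4760 nM in this assay. Compound 2 `CCCn1c(N)c(-c2nc3ccccc3[nH]2)c2nc(C#N)c(C#N)nc21` gives 45200 nM in this assay. Compound 3 `CN1CCN(CCCn2c(N)c(-c3nc4ccccc4[nH]3)c3nc(C#N)c(C#N)nc32)CC1` gives 750 nM in this assay, the lowest of the three numbers and therefore the strongest inhibition seen so far; its nearest neighbour is compound 1, and compound 2 lies furthest away. The steps among these three show how much the tail on the chain matters: a 60-fold lower number from compound 2 to compound 3 (1.78 log units; beyond the scatter), a 6.3-fold lower number from compound 1 to compound 3 (0.80 log units; beyond the scatter), and a 9.5-fold higher number from compound 1 to compound 2 (0.98 log units; beyond the scatter).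

Compound 4 `N#Cc1nc2c(-c3nc4ccccc4[nH]3)c(N)n(CCCNc3ccccc3)c2nc1C#N` differs from compound 3 in one place: anilino in place of 4-methylpiperazin-1-yl on a saturated chain carbon, three bonds along the chain from an aromatic nitrogen. The change most closely related to this is the step from compound 2 to compound 3, where adding a group at exactly this place on the chain gave the large gain just described; the step from compound 1 to compound 2 also shows that removing a ring of this kind from the chain end weakens inhibition. Compound 4 keeps a ring at the chain end but of a different kind, so a step back towards weaker inhibition is expected, though not all the way to compound 2. Compound 4 is therefore estimated at 8000 nM in this assay, with a range from 1500 nM to 40000 nM, meaning an expected step of an 11-fold higher number from compound 3 to compound 4 (1.03 log units; beyond the scatter).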

Compound 4, half-maximal inhibitory concentration: 6920 nM
Beside the measured number, compound 4's estimate is 1.2-fold (0.06 log units) above it, and the stated range covers the measured number.
By their numbers in this assay, from the lowest: compound 3; then compounds 1 and 4 (each within the scatter of the next); then compound 2.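

In this assay, putting anilino in place of 4-methylpiperazin-1-yl at the end of the propyl chain gives a 9.2-fold higher number from compound 3 to compound 4 (0.97 log units; beyond the scatter) even though both groups have 7 heavy atoms and one six-membered ring, so the kind of ring and its link to the chain matter here, not just the presence of a ring of this size. Anilino still keeps part of the gain over the bare chain end, with a 6.5-fold lower number from compound 2 to compound 4 (0.82 log units; beyond the scatter) for anilino in place of hydrogen, so the 4-methylpiperazin-1-yl group is not the only group at this place that improves on hydrogen. The comparison with the shorter pyrrolidine-bearing tail gives a 1.5-fold higher number from compound 1 to compound 4 (0.16 log units; within the scatter) and lies within the scatter, so these two tails cannot be told apart in this assay.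

Going by these compounds, it remains open whether cyclohexylamino, which has a saturated carbon ring in place of the aromatic ring of anilino, or morpholin-4-yl, which has an oxygen in place of the methyl-bearing ring nitrogen of 4-methylpiperazin-1-yl, would stay close to compound 3 or compound 4. No measurement available here explains the differences between these chain-end groups.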